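The compounds below may be only part of what the source reports. "The series", "measured", "known", "first", "only" and "open" are said of these compounds alone.

Compound 3 `CCC1=C(O)c2c(oc(-c3ccccc3OC)cc2=O)C(CC)(CC)C1=O` stands highest of the two numbers in a functional assay on KB cells (Homo sapiens) for antiproliferative activity, read by sulforhodamine B assay, with a stated time of 3 days (a higher number here means that more compound is needed for the effect, a lower number that less compound is needed), giving 40.8 uM. Among the compounds with values here, compound 2 `CCC1=C(O)c2c(oc(-c3cccc(OC)c3)cc2=O)C(CC)(CC)C1=O` gives 13.3 uM, so the step of a 3.1-fold higher number from compound 2 to compound 3 (0.49 log units; beyond the scatter) is the one measured change on the phenyl ring that moved the number. Compound 1 `CCCc1ccc(-c2cc(=O)c3c(o2)C(CC)(CC)C(=O)C(CC)=C3O)cc1` reports only a limit, > 53 uM (the limit of > 53 uM in this assay, at which 1 of the 3 values shown sits). From it, an at least 3.9-fold lower number from compound 1 to compound 2 (0.60 log units; beyond the scatter) and an at least 1.2-fold lower number from compound 1 to compound 3 (0.11 log units; that floor lies within the scatter) can be stated no more closely.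

Compound 4 `CCC1=C(O)c2c(oc(-c3ccc(O)c(C)c3C)cc2=O)C(CC)(CC)C1=O` carries 4-hydroxy-2,3-dimethylphenyl in place of 2-methoxyphenyl on an aromatic carbon. Within the data shown here, the only step bearing on this change, a 3.1-fold higher number from compound 2 to compound 3 (0.49 log units; beyond the scatter), was modest, and no hydroxy-bearing phenyl has been measured here. A step of similar size is expected, a 2.0-fold lower number from compound 3 to compound 4 (0.31 log units; beyond the scatter), toward a lower number. Compound 4 is estimated at 20 uM, within 6 uM to 60 uM.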

Compound 4, concentration for half-maximal effect: 6.5 uM
Compound 4: the middle estimate sits 3.1-fold (0.49 log units) above what was measured, within the range that was stated.
By their numbers in this assay, from the lowest: compound 4; then compound 2; then compound 3. At a limit, above all of these: compound 1.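

At the aromatic carbon next to the ring oxygen, a hydroxy-bearing aryl group gives a lower number in this assay than either methoxyphenyl group: a 6.3-fold lower number from compound 3 to compound 4 (0.80 log units; beyond the scatter) and a 2.0-fold lower number from compound 2 to compound 4 (0.31 log units; beyond the scatter). Compound 4 therefore stands lowest of the compounds shown, with both steps beyond the scatter. Compound 1 is held only at a limit, so an at least 8.1-fold lower number from compound 1 to compound 4 (0.91 log units; beyond the scatter) is a floor: the limit of > 53 uM in this assay, at which 1 of the 4 values shown sits.

As far as these compounds go, the change brings in the hydroxy and two methyl groups together, so their separate contributions stay open. A plain 4-hydroxyphenyl or a 4-aminophenyl at this position would help separate them.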